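Dropping a Methyl From the Weaker Compound

The source may report more compounds than this note shows. Statements on the series, on what has been measured and on what is new or still open speak of the compounds shown alone.

Compound 1, `COc1ccc2nc(Nc3ccnc(Nc4ccc(S(C)(=O)=O)cc4)n3)sc2c1`: 2270 nM
Compound 2, `Cc1cnc(Nc2ccc(S(C)(=O)=O)cc2)nc1Nc1nc2ccc(F)cc2s1`: 24000 nM

In a functional assay on HCT-116 cells (Homo sapiens) for antiproliferative activity, read by MTT assay, with a stated time of 48 h (on this read-out lower numbers stand for stronger inhibition and higher numbers for weaker inhibition), compound 2 gives 24000 nM, the highest of the two numbers. Compound 1 gives 2270 nM, a gap beyond the usual scatter. Compound 3, `CS(=O)(=O)c1ccc(Nc2nccc(Nc3nc4ccc(F)cc4s3)n2)cc1`, is not yet measured; it differs from compound 2 in one place: hydrogen in place of methyl on an aromatic carbon. Within the data shown here, no measured pair shows this step alone, so its size is uncertain. A move toward lower numbers is expected because compound 1, which also lacks the methyl, gives 2270 nM. Compound 3 is estimated at 6000 nM, between 1500 nM and 24000 nM. That estimate means an expected step of a 4.0-fold lower number from compound 2 to compound 3 (0.60 log units; beyond the scatter).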

Compound 3, half-maximal inhibitory concentration: 860 nM
For compound 3 the middle estimate is 7.0-fold (0.84 log units) above the measured one, and the stated range ends above it.
By their numbers in this assay, from the lowest: compound 3; then compound 1; then compound 2.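

In this assay, taking the methyl off this aromatic carbon gives a 28-fold lower number from compound 2 to compound 3 (1.45 log units; beyond the scatter) and shows that this one place on the ring can by itself shift the number strongly. The other change, fluoro in place of methoxy, gives a 2.6-fold lower number from compound 1 to compound 3 (0.42 log units; beyond the scatter) and is a smaller step. No measurement here explains why the methyl step is so large.

The compounds shown leave open how an ethyl group or an amine on this same carbon would compare with hydrogen and methyl. They also leave open whether removing the methyl gives a step of similar size when methoxy replaces fluoro.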